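A few compounds are considered here, and "the series" means these few. Any claim that something is new, unique, unknown or untested is made for them only; others in the source may bear on it.

In a functional assay on HCT-116 cells (Homo sapiens) for antiproliferative activity, read by MTT assay, with a stated time of 24 h (a lower number here means a stronger inhibitor, a higher number a weaker inhibitor), compound 3 (`COc1cc(OC)c(-c2coc3cc(OCc4cccc(Cl)c4)ccc3c2=O)cc1OC`) gives 1330 nM and compound 1 (`COc1cc(OC)c(-c2coc3cc(OCc4ccccc4)ccc3c2=O)cc1OC`) gives 2280 nM with the two within the scatter of each other. Compound 2 (`COc1cc(OC)c(-c2coc3cc(OCc4ccc([N+](=O)[O-])cc4)ccc3c2=O)cc1OC`) reads > 10000 nM and this is a limit of the assay. Compound 3 sits clear of that limit, with an at least 7.5-fold lower number from compound 2 to compound 3 (0.87 log units; beyond the scatter) on record.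

Compound 4 (`COc1cc(OC)c(-c2coc3cc(OCc4ccccc4Cl)ccc3c2=O)cc1OC`) keeps the same atoms joined differently: 2-chlorophenyl in place of 3-chlorophenyl on a saturated chain carbon bound to an oxygen on an aromatic ring with 2-chlorophenyl in place of 3-chlorophenyl on a saturated chain carbon bound to an oxygen on an aromatic ring.

Among the compounds with values here, two measured steps bear on this change. Adding a chloro gave a 1.7-fold lower number from compound 1 to compound 3 (0.23 log units; within the scatter) while nitro in place of hydrogen gave an at least 4.3-fold higher number from compound 1 to compound 2 (0.64 log units; beyond the scatter) as the only larger change on that aryl group, and with a different substituent. Within the data shown here, no measured step moves a chloro. The chloro step from compound 1 is the closer guide, so no step beyond the scatter is expected. An estimated 1.2-fold higher number from compound 3 to compound 4 (0.08 log units; within the scatter) is the working expectation. For compound 4 the expected value is 1600 nM with an estimated range from 600 nM to 4500 nM as the working figures.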

Compound 4, half-maximal inhibitory concentration: 2450 nM
For compound 4 the middle estimate is 1.5-fold (0.19 log units) below the measured one; measured number inside the range.
By their numbers in this assay, from the lowest: compounds 3, 1 and 4 (each within the scatter of the next). At a limit, above all of these: compound 2.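

In this assay, within the data shown here, 2-chlorophenyl in place of 3-chlorophenyl gives a 1.8-fold higher number from compound 3 to compound 4 (0.27 log units; within the scatter), so this is the first measured move of the chloro at this place on the saturated chain carbon, and it produces no step that can be read. Against the unsubstituted phenyl, the new chlorophenyl gives a 1.1-fold higher number from compound 1 to compound 4 (0.03 log units; within the scatter), so this chloro, like the one in compound 3, does not separate from compound 1. The separation from the 4-nitrophenyl compound now holds for a second chlorophenyl, with an at least 4.0-fold lower number from compound 2 to compound 4 (0.61 log units; beyond the scatter).

Still open, going by these compounds, is whether that separation belongs to the nitro group itself, and how a phenyl carrying an amine or a carboxylic acid in place of the chloro would read. The value for compound 2 remains a limit, not a number: the limit of > 10000 nM in this assay, at which 1 of the 4 values shown sits.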